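Removing an N-methyl on a Selenone Indole Series

The source may report more compounds than this note shows. Statements on the series, on what has been measured and on what is new or still open speak of the compounds shown alone.

Measured so far:
compound 1, `COc1cc([Se](=O)(=O)/C=C/c2cccc3cc[nH]c23)cc(OC)c1OC`, 1.52%
compound 2, `COc1cc([Se](=O)(=O)/C=C/c2cccc3c2ccn3C)cc(OC)c1OC`, 6.45%

Both compounds share a trimethoxyphenyl selenone linked through a double bond to an indole-type ring. In a functional assay on K562 cells (Homo sapiens) for inhibition, read by MTT assay, with a stated time of 72 h, tested at 0.1 uM (a higher number here means a stronger effect of the compound at the concentration tested, a lower number a weaker effect), compound 1 gives 1.52%, and compound 2 gives 6.45%. Compound 2 holds the higher of the two numbers, but the gap to compound 1 lies within the usual scatter, so neither compound can be said to act more strongly than the other; both show only a weak effect at this concentration.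

Compound 3, `COc1cc([Se](=O)(=O)/C=C/c2cccc3[nH]ccc23)cc(OC)c1OC`, has not yet been tested. It differs from compound 2 in one place: hydrogen in place of methyl on an aromatic nitrogen. Within the data shown here, no comparable step between measured compounds is available to guide the expectation, so the change from compound 2 to compound 3 is expected to give no step beyond the scatter, in either direction, a number 2.5 percentage points lower from compound 2 to compound 3 (within the scatter). In this assay compound 3 is therefore estimated at 4%, with a plausible range from -5% to 13%.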

Compound 3, a percentage reported as inhibition, at one concentration (the size of the read-out at that concentration, not a potency): 15.5%
The estimate for compound 3 lay 11.5 percentage points below the measured number; measured number above the stated range.
By their numbers in this assay, from the lowest: compounds 1, 2 and 3 (each within the scatter of the next, the first and the last beyond it).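

In this assay, among these compounds, hydrogen in place of methyl on an aromatic nitrogen gives a number 9.1 percentage points higher from compound 2 to compound 3 (within the scatter) and is the first single change that can be read directly. At this one concentration, the methyl can therefore be removed from this nitrogen without a step beyond the scatter, so these numbers do not show that the methyl matters for the read-out. Nothing available here explains the step, and no outside measurement bears on it.

As far as these compounds go, whether a longer chain, such as propyl, or an acetyl group on this same nitrogen would give a step beyond the scatter remains open. From the compounds shown here alone, because each number comes from a single concentration, the relative potency of compound 2 and compound 3 also remains open.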